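A few compounds are considered here, and "the series" means these few. Any claim that something is new, unique, unknown or untested is made for them only; others in the source may bear on it.

Measured so far in an ADME assay on the whole organism (Mus musculus, strain CD1) for pharmacokinetics, read by LC-MS, with a stated time of 24 h, at a dose of 5 mg/kg by the oral route; on this read-out lower numbers stand for lower oral bioavailability and higher numbers for higher oral bioavailability:
- compound 1 `CCOc1cc2[nH]c(Cc3nn(CC(=O)O)c(=O)c4ccccc34)nc2cc1Cl`: 4%
- compound 2 `O=C(O)Cc1nn(Cc2cn3cc(OCC4CC4)c(Cl)cc3n2)c2ccccc2c1=O`: 14%

Compound 2 gives 14% and compound 1 gives 4%. These two values lie within the usual scatter of each other, so the numbers do not separate the two compounds, and both sit in the low part of the scale.

The next compound to be measured is compound 3 `CCC(C(=O)O)c1nn(Cc2cn3cc(OCC4CC4)c(Cl)cc3n2)c2ccccc2c1=O`. Its difference from compound 2 is ethyl in place of hydrogen on a saturated chain carbon bound to an aromatic carbon and a carbonyl carbon. Cut one bond further out, the same difference reads carboxymethyl to 1-carboxypropyl.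

Among the compounds with values here, no two measured compounds differ in one place only, so no measured step bears on this change, and the expectation starts from compound 2 at 14%. In this assay the expected outcome is a small upward move that stays within the scatter, and the estimated step is a number 6 percentage points higher from compound 2 to compound 3 (within the scatter). For compound 3 the estimate is 20%, with an expected range from 7% to 45%.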

Compound 3, oral bioavailability: 18%
Compound 3: the middle estimate sits 2 percentage points above what was measured; low and high end bracket the measured number.
By their numbers in this assay, from the lowest: compounds 1, 2 and 3 (each within the scatter of the next, the first and the last beyond it).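

In this assay the series now has its first comparison of two compounds that differ in one place: ethyl in place of hydrogen on a saturated chain carbon bound to an aromatic carbon and a carbonyl carbon gives a number 4 percentage points higher from compound 2 to compound 3 (within the scatter) and so does not separate the two compounds. This position therefore accepts the change from carboxymethyl to 1-carboxypropyl, with its 2 added carbon atoms and no ring, without a difference that this read-out can resolve, although this rests on a single pair and supports no wider pattern. No measurement available here accounts for this outcome.

Still open, on these data alone, is whether a methyl group, a fluorine atom or a longer chain such as butyl on the same saturated chain carbon would give a value that stands clear of compound 2 at 14% in this assay. Also open, as far as these compounds go, is whether replacing the carboxylic acid with a primary amide or a tetrazole, with or without the ethyl group, would give a value outside the low part of the scale.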